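The source may hold more compounds than are shown below. What is called first, only, known or untested is meant among the compounds shown, and "the series" means these compounds.

Compound 2, drawn as `Cc1ccc(-c2cc(C3=CC(=O)C=CC3=O)n(-c3ccc(S(N)(=O)=O)cc3)n2)cc1`, is examined in a functional assay on cells (Cancer cell lines, Homo sapiens) for cytotoxicity, read by sulforhodamine B assay, with a stated time of 48 h (on this read-out higher numbers stand for weaker inhibition of growth and lower numbers for stronger inhibition of growth), where compound 2 gives 51500 nM. Going by the values given here, of the two compounds measured so far, compound 2 carries the higher number; compound 1, drawn as `NS(=O)(=O)c1ccc(-n2nc(-c3ccc(Cl)cc3)cc2-c2cc(O)ccc2O)cc1`, gives in this assay 16700 nM, and the gap between the two lies beyond the usual scatter. Compound 3, drawn as `NS(=O)(=O)c1ccc(-n2nc(-c3ccc(Cl)cc3)cc2C2=CC(=O)C=CC2=O)cc1`, differs from compound 2 by chloro in place of methyl on an aromatic carbon. Among the compounds with values here, no measured pair shows this single change, so its effect is uncertain; a step from compound 2 to compound 3 of a 1.5-fold lower number from compound 2 to compound 3 (0.17 log units; within the scatter) is expected, not clearly beyond the scatter. Compound 3 is accordingly estimated at 35000 nM, within a range from 12000 nM to 90000 nM.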

Compound 3, concentration for 50% growth inhibition: 21900 nM
Beside the measured number, compound 3's estimate is 1.6-fold (0.20 log units) above it; the measured number falls inside the stated range.
By their numbers in this assay, from the lowest: compounds 1 and 3 (each within the scatter of the next); then compound 2.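

In this assay, chloro in place of methyl on an aromatic carbon, para to a large group, gives a 2.4-fold lower number from compound 2 to compound 3 (0.37 log units; beyond the scatter), so this position responds modestly to this change. Exchanging the aromatic ring of compound 1 for the non-aromatic ring of compound 3 gives a 1.3-fold higher number from compound 1 to compound 3 (0.12 log units; within the scatter), which does not separate the two compounds. Nothing available accounts for either step.

The compounds shown leave open how a methoxy group or an amine at this position would compare with chloro and methyl. Going by these compounds, whether chloro in place of methyl gives a similar step with the aromatic ring of compound 1 also remains open.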